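Pyridin-2-yl to 3-methyl-1,2-oxazol-5-yl: expected clearance

The compounds below may be only part of what the source reports. "The series", "measured", "known", "first", "only" and "open" are said of these compounds alone.

Three compounds sharing one core have been run in an ADME assay on microsomes from liver (Homo sapiens) for metabolic stability, using NADPH, with a stated time of 60 min; on this read-out higher numbers stand for fast clearance and lower numbers for slow clearance. Compound 1 `O=C(Nc1cccc(C(=O)O)c1)Nc1ccc(F)c(C(F)(F)F)c1` gives < 7 uL/min, which is a limit of this assay rather than a number, as the limit of < 7 uL/min in this assay, at which 1 of the 3 values shown sits, records. Compound 2 `O=C(Nc1ccc(F)c(C(F)(F)F)c1)Nc1cnccn1` gives 210 uL/min in this assay. Compound 3 `O=C(Nc1ccc(F)c(C(F)(F)F)c1)Nc1ccccn1` gives 188 uL/min in this assay, and the step of a 1.1-fold lower number from compound 2 to compound 3 (0.05 log units; within the scatter) lies within the scatter, so compound 2 and compound 3 cannot be told apart. Among the two numbers shown, compound 3 has the lowest one, with the third entry being a limit.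

Compound 4 `Cc1cc(NC(=O)Nc2ccc(F)c(C(F)(F)F)c2)on1` has not yet been measured. It differs from compound 3 as follows: 3-methyl-1,2-oxazol-5-yl in place of pyridin-2-yl on an amide-type nitrogen. Among the measured compounds shown here, the one measured step that bears on this change, a 1.1-fold lower number from compound 2 to compound 3 (0.05 log units; within the scatter), exchanged one aromatic ring for another on the same amide-type nitrogen and moved the number little. For the measured compounds named here, compound 1 carries a different kind of change and its value is a limit, so it offers no guide for this step. The step of a 1.0-fold lower number from compound 3 to compound 4 (0.02 log units; within the scatter) is therefore expected to stay within the scatter. The estimate for compound 4 in this assay is 180 uL/min, expected to fall within 70 uL/min to 400 uL/min.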

Compound 4, intrinsic clearance in a liver preparation (reported as CLH), per the amount of preparation that the assay uses in the Homo sapiens assay: 73 uL/min
Beside the measured number, compound 4's estimate is 2.5-fold (0.39 log units) above it, and the stated range covers the measured number.
By their numbers in the Homo sapiens assay, from the lowest: compound 4; then compounds 3 and 2 (each within the scatter of the next). At a limit, below all of these: compound 1.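

In the Homo sapiens assay, this place on the amide-type nitrogen proves responsive after all: 3-methyl-1,2-oxazol-5-yl in place of pyridin-2-yl gives a 2.6-fold lower number from compound 3 to compound 4 (0.41 log units; beyond the scatter), and in place of pyrazin-2-yl it gives a 2.9-fold lower number from compound 2 to compound 4 (0.46 log units; beyond the scatter), whereas the earlier exchange of one six-membered aromatic ring for another had stayed within the scatter. In a physicochemical assay for solubility, read by nephelometry, in phosphate buffer, measured as kinetic solubility, at pH 6.5 (a higher number here means a more soluble compound, a lower number a less soluble compound), compound 3 gives < 1.6 ug/mL, which is a limit of the assay and not a number. In the physicochemical assay compound 4 gives 6.3 ug/mL, a measured number, so the five-membered ring with its methyl group is the only one of these two that yields a reading on this scale.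

The compounds shown leave open whether the step in clearance belongs to the 1,2-oxazole ring itself or to its methyl group, and whether an amine or an ethyl group in that methyl group's place would keep, extend or undo it. Nothing measured here bears on what lies behind the step in clearance.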